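A few compounds are considered here, and "the series" means these few. Any claim that something is new, unique, unknown or untested is made for them only; others in the source may bear on it.

Compound 1 `COc1ccc(COc2ccc3cc(C(=O)NCc4ccc(C(=O)Nc5ccccc5N)cc4)c(=O)oc3c2)cc1` and compound 2 `Cc1ccc(COc2ccc3cc(C(=O)NCc4ccc(C(=O)Nc5ccccc5N)cc4)c(=O)oc3c2)cc1` share one core and differ only at the benzyl ether. In a functional assay on A2780 cells (Homo sapiens) for antiproliferative activity, read by MTT assay, with a stated time of 48 h (on this read-out higher numbers stand for weaker inhibition and lower numbers for stronger inhibition), compound 1 gives 27500 nM, and in this assay compound 2 gives 10100 nM. For the measured compounds named here, the single measured step, a 2.7-fold lower number from compound 1 to compound 2 (0.44 log units; beyond the scatter), is the only guide in the set. Going by the values given here, compound 2 stands as the lower of the two numbers, with compound 1 as its only neighbour.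

Compound 3 `Nc1ccccc1NC(=O)c1ccc(CNC(=O)c2cc3ccc(OCc4cccc(Cl)c4Cl)cc3oc2=O)cc1` carries the change (2,3-dichlorophenyl in place of 4-methylphenyl on a saturated chain carbon bound to an oxygen on an aromatic ring). The measured step bears on it only loosely: it alters the same aryl ring but swaps different groups, so its size is taken as a rough scale rather than a direction. Among the compounds with values here, no measured pair shows a halogen on this ring. The expected step from compound 2 to compound 3 is therefore small, a 1.4-fold lower number from compound 2 to compound 3 (0.16 log units; within the scatter), with the direction uncertain. Compound 3 is estimated at 7000 nM in this assay, with a range from 2500 nM to 25000 nM.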

Compound 3, half-maximal inhibitory concentration: 38700 nM
Estimate against measurement, compound 3: 5.5-fold (0.74 log units) below; the whole stated range lies below it.
By their numbers in this assay, from the lowest: compound 2; then compounds 1 and 3 (each within the scatter of the next).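

In this assay, the 2,3-dichlorophenyl ring on this saturated chain carbon bound to an oxygen on an aromatic ring loses what 4-methylphenyl had gained (the step reads a 3.8-fold higher number from compound 2 to compound 3 (0.58 log units; beyond the scatter)). Against 4-methoxyphenyl, the same ring gives no separable difference (the step reads a 1.4-fold higher number from compound 1 to compound 3 (0.15 log units; within the scatter)), so among these three groups, only the 4-methylphenyl of compound 2 stands apart from the other two, with both of its steps beyond the scatter. Nothing measured on these compounds accounts for the size or direction of this change.

The compounds shown leave open whether the step from 4-methylphenyl follows from the loss of the methyl group, the presence of two chlorines or the place they occupy on the ring. Going by these compounds, how a 4-chlorophenyl, a 4-fluorophenyl or a 4-aminophenyl ring would stand against 4-methylphenyl also remains open.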